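Removing a Methyl Group from a Nitro-Substituted Dienone

A few compounds are considered here, and "the series" means these few. Any claim that something is new, unique, unknown or untested is made for them only; others in the source may bear on it.

Measured compounds:
- compound 1, `Cc1ccc(/C=C2\CCC/C(=C\c3ccc([N+](=O)[O-])cc3)C2=O)cc1`: 5.08
- compound 2, `COc1cc(/C=C2\CCC/C(=C\c3cccc([N+](=O)[O-])c3)C2=O)cc(OC)c1OC`: 5.06
- compound 3, `O=C1/C(=C/c2ccc(Cl)cc2)CCC/C1=C\c1cccc([N+](=O)[O-])c1`: 5.06

Of the compounds shown here, three built on a shared core have been measured in a physicochemical assay for lipophilicity; on this read-out lower numbers stand for lower lipophilicity and higher numbers for higher lipophilicity. Compound 1 gives 5.08 in this assay. Compound 2 gives 5.06, and compound 3 gives 5.06. Compound 1 holds the highest of the three numbers, but the gaps to compound 2 and to compound 3 both lie within the scatter of this kind of measurement, so the three values are best read as indistinguishable.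

Compound 4, `O=C1/C(=C/c2ccccc2)CCC/C1=C\c1ccc([N+](=O)[O-])cc1`, has not yet been measured in this assay. Against compound 1 the change is hydrogen in place of methyl on an aromatic carbon; it is a single hydrogen in place of methyl on an aromatic carbon, so that a 4-methylphenyl becomes a phenyl. Among the measured compounds shown here, no pair among the measured compounds shows exactly this exchange, so its effect must be judged from general experience rather than from the numbers at hand. Losing one carbon with no change in donors, acceptors or charge is usually expected to lower a partition coefficient by a modest but real amount, beyond the scatter. The step from compound 1 to compound 4 is therefore estimated at a number 0.48 log units lower from compound 1 to compound 4 (beyond the scatter). Compound 4 is expected to give about 4.6 in this assay, within a range from 4.2 to 5.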

Compound 4, partition coefficient: 5.08
Estimate against measurement, compound 4: 0.48 log units below, outside the stated range (above it).
By their numbers in this assay, from the lowest: compounds 2, 3, 1 and 4 (each within the scatter of the next).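

In this assay, among the compounds shown here, the first pair that differs in one place shows that hydrogen in place of methyl on this aromatic carbon, which turns 4-methylphenyl into phenyl, gives no change at the digits printed from compound 1 to compound 4 (within the scatter) and leaves the two compounds indistinguishable on this read-out. The earlier compounds shown here could not show this, since no two of them differed by a single change and their close values could not be tied to any one group. For this pair, then, the methyl at this position can be removed without any visible shift in the number, although the data offer no measurement that explains why.

This single pair cannot show whether the same exchange would behave the same way on a compound with different groups elsewhere on the shared core, such as compound 2 or compound 3. It also leaves open whether a group of another kind at this position, such as an amine, a carboxylic acid or a longer chain like butyl, would move the read-out beyond the scatter or leave it just as flat.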